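From a Chain-Linked Pyridine to a Fluorophenyl Amide

The source may report more compounds than this note shows. Statements on the series, on what has been measured and on what is new or still open speak of the compounds shown alone.

Compound 1 `O=C(Cc1ccccn1)N[C@H]1CCC[C@H](NC(=O)c2cccc(Cl)c2)C1` was tested in a functional assay on HEK293 cells for antagonist activity at metabotropic glutamate receptor 5 (Homo sapiens), read by FLIPR and calcium flux; on this read-out higher numbers stand for weaker inhibition and lower numbers for stronger inhibition. In this assay compound 1 gives only a limit, > 10000 nM, not a number. Compound 1 sits at the limit of > 10000 nM in this assay, at which 1 of the 3 values shown sits. Two related compounds carry their aromatic rings directly on both carbonyl carbons: compound 2 `O=C(N[C@@H]1CCC[C@@H](NC(=O)c2ccccn2)C1)c1cccc(Cl)c1` gives 62 nM in this assay, and compound 3 `O=C(N[C@H]1CCC[C@H](NC(=O)c2ccccn2)C1)c1ccccn1` gives 1150 nM. Compound 4 `O=C(N[C@H]1CCC[C@H](NC(=O)c2cccc(Cl)c2)C1)c1ccc(F)cc1` has not been measured. It differs from compound 1 by 4-fluorophenyl in place of (pyridin-2-yl)methyl on a carbonyl carbon, so that compound 4, like compound 2 and compound 3, carries an aromatic ring directly on each carbonyl carbon. The expected step is an at least 33-fold lower number from compound 1 to compound 4 (1.52 log units; beyond the scatter), toward stronger inhibition, though its size is uncertain since compound 1 gives only a limit. Compound 4 is estimated at about 300 nM, within a range from 50 nM to 3000 nM.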

Compound 4, half-maximal inhibitory concentration: 194 nM
Compound 4: the middle estimate sits 1.5-fold (0.19 log units) above what was measured; low and high end bracket the measured number.
By their numbers in this assay, from the lowest: compound 2; then compound 4; then compound 3. At a limit, above all of these: compound 1.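

At this carbonyl carbon, 4-fluorophenyl in place of (pyridin-2-yl)methyl gives an at least 51-fold lower number from compound 1 to compound 4 (1.71 log units; beyond the scatter), a measurable value in this assay. A ring nitrogen in this group is therefore not needed for inhibition on the core of compound 1. The true size of the step stays unknown because compound 1 gives only a limit, not a number: the limit of > 10000 nM in this assay, at which 1 of the 4 values shown sits.

This one step swaps the ring nitrogen, the connecting carbon and the fluorine together, so their separate contributions stay unresolved. A plain phenyl or a benzyl group at this position would help to separate them.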